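Cyclopropyl for Phenoxy on a Second Core

A few compounds are considered here, and "the series" means these few. Any claim that something is new, unique, unknown or untested is made for them only; others in the source may bear on it.

Measured compounds in a functional assay on MCF7 cells (Homo sapiens) for inhibition, read by resazurin assay, with a stated time of 72 h; on this read-out lower numbers stand for stronger inhibition and higher numbers for weaker inhibition:
compound 1, `COc1ccc(C2C(Oc3ccccc3)C(=O)N2c2cc(OC)c(OC)c(OC)c2)cc1`, gives 23 nM;
compound 2, `COc1ccc(C2C(C3CC3)C(=O)N2c2cc(OC)c(OC)c(OC)c2)cc1`, gives 120 nM;
compound 3, `COc1cc(N2C(=O)C(Oc3ccccc3)C2c2ccc(SC)cc2)cc(OC)c1OC`, gives 152 nM.

Compound 1 and compound 2 differ by one change, (cyclopropyl in place of phenoxy on a saturated ring carbon), and this change made the step of a 5.2-fold higher number from compound 1 to compound 2 (0.72 log units; beyond the scatter). Compound 3 differs from compound 1 at another point, (methylsulfanyl in place of methoxy on an aromatic carbon), with the step of a 6.6-fold higher number from compound 1 to compound 3 (0.82 log units; beyond the scatter). Among the measured compounds shown here, compound 2 and compound 3 differ at both points, and no step between them is broken down here; their two values lie within the usual scatter of each other.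

Compound 4, `COc1cc(N2C(=O)C(C3CC3)C2c2ccc(SC)cc2)cc(OC)c1OC`, is not yet measured in this assay. It differs from compound 3 by cyclopropyl in place of phenoxy on a saturated ring carbon, the same kind of change as that from compound 1 to compound 2, though the place is not identical word for word: in compound 3 the saturated ring carbon is next to the ring atom that bears a 4-(methylsulfanyl)phenyl group, whereas in compound 1 it is next to the ring atom that bears a 4-methoxyphenyl group. For the measured compounds named here, on the strength of the single earlier instance, compound 4 is expected to show a step of about the same size, a 4.9-fold higher number from compound 3 to compound 4 (0.69 log units; beyond the scatter), because compound 1 to compound 2 gave a 5.2-fold higher number from compound 1 to compound 2 (0.72 log units; beyond the scatter). Compound 4 is therefore estimated at 750 nM, with a range from 250 nM to 2200 nM.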

Compound 4, half-maximal inhibitory concentration: 131 nM
Compound 4: the middle estimate sits 5.7-fold (0.76 log units) above what was measured; measured number outside the range, below it.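

In this assay, cyclopropyl in place of phenoxy on a saturated ring carbon gave a 1.2-fold lower number from compound 3 to compound 4 (0.06 log units; within the scatter), so the step seen on the core of compound 1 did not carry over to the core of compound 3: the same change on two cores in this assay, a 5.2-fold higher number (0.72 log units; beyond the scatter) from compound 1 to compound 2 and a 1.2-fold lower number (0.06 log units; within the scatter) from compound 3 to compound 4, 6.1-fold (0.78 log units) apart, beyond the scatter of two such steps Methylsulfanyl in place of methoxy on an aromatic carbon gave a 1.1-fold higher number from compound 2 to compound 4 (0.04 log units; within the scatter), and this change likewise did not carry from one core to the other: the same change on two cores in this assay, a 6.6-fold higher number (0.82 log units; beyond the scatter) from compound 1 to compound 3 and a 1.1-fold higher number (0.04 log units; within the scatter) from compound 2 to compound 4, 6.1-fold (0.78 log units) apart, beyond the scatter of two such steps The two changes are therefore not independent in these four compounds, but a single pair of steps for each change does not show why, nor how either change would behave on any further core.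

Going by these compounds, it remains open whether other groups on the saturated ring carbon, such as a methyl, an ethyl or a benzyloxy group, would depend on the aromatic group in the same way. On these data alone, it also remains open whether the same holds when a chlorine or an ethoxy group stands in place of methoxy on the aromatic carbon.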